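The compounds below may be only part of what the source reports. "The series", "measured", "known", "first", "only" and "open" are said of these compounds alone.

Measured in an ADME assay on HEK293 cells (Homo sapiens) for cytotoxicity, with a stated time of 6 h; on this read-out higher numbers stand for lower toxicity in this test and lower numbers for higher toxicity in this test:
- compound 1 `CCCCNc1nc(N)nc2cccc(CCc3ccccc3)c12`: > 25000 nM (a limit of the assay)
- compound 2 `CCCCNc1nc(N)nc2cccc(OCCOC)c12`: 10000 nM

Among the measured compounds shown here, compound 2 holds the only actual number so far, 10000 nM. The other entry offers only (the limit of > 25000 nM in this assay, at which 1 of the 2 values shown sits).

Next is compound 3 `CCCCNc1nc(N)nc2cccc(OCc3ccccn3)c12`, with the change pyridin-2-yl in place of methoxymethyl on a saturated chain carbon bound to an oxygen on an aromatic ring.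

For the measured compounds named here, one measured step bears on this, and only loosely: an at least 2.5-fold lower number from compound 1 to compound 2 (0.39 log units; beyond the scatter), with 2-methoxyethoxy in place of phenethyl. On these data alone, its true size stays open, given (the limit of > 25000 nM in this assay, at which 1 of the 2 values shown sits). Compound 3 shares with compound 1 an aromatic ring in this substituent, so a partial move back towards higher numbers is expected, probably not beyond the scatter. The expected step is a 1.4-fold higher number from compound 2 to compound 3 (0.15 log units; within the scatter). The estimate for compound 3 is 14000 nM, with an expected range of 6000 nM to 25000 nM.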

Compound 3, half-maximal cytotoxic concentration: > 25000 nM
Compound 3 gave a limit, no number; the forecaster's own chance of this, stated with the estimate: 25%; middle value at least 1.7-fold (0.25 log units) from the limit.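

In this assay, the change from methoxymethyl to pyridin-2-yl on the saturated chain carbon bound to an oxygen on an aromatic ring gives an at least 2.5-fold higher number from compound 2 to compound 3 (0.39 log units; beyond the scatter). Among the compounds shown here, the oxygen link therefore does not by itself go with the lower number, since compounds 2 and 3 both carry it; among the three compounds, the only actual number belongs to compound 2, the one whose substituent has no ring. Compound 3 gives > 25000 nM, which is a limit of the assay and not a number.

On these data alone, the step from compound 1 to compound 3 cannot be read, and the full size of the step to compound 3 stays open: the limit of > 25000 nM in this assay, at which 2 of the 3 values shown sit. Also open is how a phenyl group in place of pyridin-2-yl on this carbon, or an amine or a carboxylic acid at the end of the chain, would read out here.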